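The compounds below may be only part of what the source reports. "The series", "measured", "known", "first", "only" and "open" are said of these compounds alone.

Three compounds of this series have been examined in a functional assay on HepG2 cells (Homo sapiens) for inhibition, read by sulforhodamine B assay, with a stated time of 72 h; on this read-out higher numbers stand for weaker inhibition and lower numbers for stronger inhibition. Compound 1, of structure `CC(C)Cc1ccc(C(C)c2n[nH]c(=S)n2N)cc1`, gave no number in this assay and was recorded as "not active" (no number reported). Compound 3, of structure `COc1ccc2cc(C(C)c3n[nH]c(=S)n3N)ccc2c1`, gave in this assay 40000 nM. Compound 2, of structure `CC(c1ccc(-c2ccccc2)c(F)c1)c1nnc2n1N=C(c1ccc(Cl)cc1Cl)CS2`, gave in this assay 8600 nM, the lower of the two numbers reported, and its gap to compound 3 lies beyond the scatter of repeated measurements. Compound 2 therefore stands at the stronger end of what has been measured so far.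

Compound 4, of structure `CC(c1ccc(-c2ccccc2)c(F)c1)c1nnc2n1N=C(c1ccc(F)cc1)CS2`, has not yet been measured. It differs from compound 2 in one place: 4-fluorophenyl in place of 2,4-dichlorophenyl on a carbon with a double bond to nitrogen. Among the measured compounds shown here, no pair of measured compounds shows the effect of this change, so any expectation rests on the single value of compound 2 alone. The account expects a modest step toward a higher number in this assay, one that may not exceed the scatter, so that the step from compound 2 to compound 4 is estimated at a 1.7-fold higher number from compound 2 to compound 4 (0.24 log units; within the scatter). Compound 4 is accordingly expected to give about 15000 nM, within a range from 4000 nM to 50000 nM, in this assay.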

Compound 4, half-maximal inhibitory concentration: 5100 nM
Compound 4: middle estimate off by 2.9-fold (0.47 log units), on the high side; measured number inside the range.
By their numbers in this assay, from the lowest: compounds 4 and 2 (each within the scatter of the next); then compound 3.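

Among the compounds shown here, the step of a 1.7-fold lower number from compound 2 to compound 4 (0.23 log units; within the scatter) is the first reading of any change at this position in this assay, and it concerns 4-fluorophenyl in place of 2,4-dichlorophenyl on a carbon with a double bond to nitrogen. The two values cannot be told apart, so on this read-out the position holds either aryl group, with its different halogen atoms and one heavy atom fewer in the entering group, without a difference that exceeds the scatter of repeated measurements. Nothing measured on these compounds bears on why the exchange leaves the number within the scatter.

As far as these compounds go, both groups at this position are halogen-bearing phenyl rings, so it remains open whether an unsubstituted phenyl, a morpholine, a carboxylic acid or a simple methyl group would keep the number in the same region or move it beyond the scatter. Compound 1 and compound 3 differ from compound 2 and compound 4 in more than one place, which leaves the contribution of the rest of the structure, including the biphenyl part with its fluorine, open as well.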